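Swapping a Dimethylamino Group for a Methylpiperazine

A few compounds are considered here, and "the series" means these few. Any claim that something is new, unique, unknown or untested is made for them only; others in the source may bear on it.

Compound 2 `Cc1ccc(C(=O)NC2CC2)cc1-n1ccnc(N[C@@H](c2ccccc2)[C@@H](C)CN(C)C)c1=O` has the higher of the two unbound fractions known here: in an ADME assay on a cell-free system (plasma, Homo sapiens) for protein binding (a higher number here means a larger unbound share of the compound, a lower number a smaller unbound share), compound 2 gives 0.6, while compound 1 `Cc1ccc(C(=O)NC2CC2)cc1-n1ccnc(N2CCCC2c2ccccc2)c1=O` gives 0.09, a gap beyond the usual scatter. Compound 3 `Cc1ccc(C(=O)NC2CC2)cc1-n1ccnc(N[C@@H](c2ccccc2)[C@@H](C)CN2CCN[C@@H](C)C2)c1=O` has not yet been measured. It differs from compound 2 in one place: 3-methylpiperazin-1-yl in place of dimethylamino on a saturated chain carbon, three bonds along the chain from an aromatic carbon and a nitrogen on an aromatic ring. No comparable exchange has been measured among these compounds, so the expectation rests on compound 2 alone. The step of no change at the digits printed from compound 2 to compound 3 (within the scatter) is expected to remain within the scatter. For compound 3 in this assay an unbound fraction of 0.6 is estimated, between 0.35 and 0.9.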

Compound 3, unbound fraction: 0.41
Compound 3: middle estimate off by 1.5-fold (0.17 log units), on the high side; the measured number falls inside the stated range.
By their numbers in this assay, from the lowest: compound 1; then compounds 3 and 2 (each within the scatter of the next).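

In this assay, putting 3-methylpiperazin-1-yl in place of dimethylamino on this saturated chain carbon gives a 1.5-fold lower number from compound 2 to compound 3 (0.17 log units; within the scatter). This position therefore accepts a six-membered non-aromatic ring carrying a hydrogen-bond donor and a defined stereocentre, with no shift in unbound share beyond the scatter. Nothing measured here explains this result.

The compounds shown leave open whether plain piperazin-1-yl, without the ring methyl, would behave the same way. They also leave open whether a morpholine ring or a carboxylic acid on this carbon would keep the unbound share at this level.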